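This account rests on a few compounds, and the source may have more. Where it says the series, first, only, none or still open, it means among the compounds named here.

Values in a functional assay on cells (leukaemia cell line, Homo sapiens) for inhibition, read by sulforhodamine B assay, with a stated time of 48 h; a higher number here means a weaker inhibitor of growth, a lower number a stronger inhibitor of growth:
- Compound 1 `O=S(=O)(Nc1ccc(Cl)cc1Cl)c1ccc(-c2cnc(C3CC3)o2)cc1`: 74500 nM
- Compound 2 `Cc1cc(NS(=O)(=O)c2ccc(-c3cnc(C4CC4)o3)cc2)ccc1Cl`: 33400 nM
- Compound 3 `O=S(=O)(Nc1cc(F)cc(Cl)c1)c1ccc(-c2cnc(C3CC3)o2)cc1`: 77500 nM

Compound 3 and compound 1 share the top of the three numbers, level within the scatter: a 1.0-fold higher number from compound 1 to compound 3 (0.02 log units; within the scatter). Compound 2 is the only one that separates from the other two, as seen in a 2.2-fold lower number from compound 1 to compound 2 (0.35 log units; beyond the scatter) and a 2.3-fold higher number from compound 2 to compound 3 (0.37 log units; beyond the scatter).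

The next compound is compound 4 `O=S(=O)(Nc1ccc(I)c(Cl)c1)c1ccc(-c2cnc(C3CC3)o2)cc1`. The change is 3-chloro-4-iodophenyl in place of 3-chloro-5-fluorophenyl on a sulfonamide nitrogen, with 3-chloro-4-iodophenyl in place of 3-chloro-5-fluorophenyl on a sulfonamide nitrogen, and the shared core stays untouched. Going by the values given here, no measured compound carries an iodine, so the three values give no direct reading of this group.

Among the compounds with values here, the only guide is the spread seen so far on changing the group on the sulfonamide nitrogen. The largest move is a 2.3-fold higher number from compound 2 to compound 3 (0.37 log units; beyond the scatter), which is modest, and the smallest is a 1.0-fold higher number from compound 1 to compound 3 (0.02 log units; within the scatter). A step of similar modest size or none beyond the scatter is therefore expected in this assay. With compound 3 at 77500 nM, the top of the three numbers, a lower number is the likelier direction.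

The estimated change is a 1.6-fold lower number from compound 3 to compound 4 (0.21 log units; within the scatter). For compound 4 the expected value is 48000 nM, with an estimated range from 20000 nM to 100000 nM.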

Compound 4, concentration for total growth inhibition: 19600 nM
Estimate against measurement, compound 4: 2.4-fold (0.39 log units) above; the whole stated range lies above it.
By their numbers in this assay, from the lowest: compounds 4 and 2 (each within the scatter of the next); then compounds 1 and 3 (each within the scatter of the next).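

Going by these compounds alone, changing the group on the sulfonamide nitrogen can move the number further than the earlier compounds showed: in this assay the 3-chloro-4-iodophenyl group gives a 4.0-fold lower number from compound 3 to compound 4 (0.60 log units; beyond the scatter) and also a 3.8-fold lower number from compound 1 to compound 4 (0.58 log units; beyond the scatter) and both steps are larger than any step among compounds 1, 2 and 3. The iodine-bearing group does not open a new level, however, since this assay shows a 1.7-fold lower number from compound 2 to compound 4 (0.23 log units; within the scatter) and so compound 4 stands level with compound 2. The four compounds therefore fall into two pairs, compounds 2 and 4 with the lower numbers and compounds 1 and 3 with the higher, and iodine is not needed to reach the lower pair, as the 4-chloro-3-methylphenyl group of compound 2 carries none.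

Still open, on these data alone, is whether a bromine, a trifluoromethyl group, an amine or a carboxylic acid on this aryl ring would take the number below the level of compounds 2 and 4 or return it to that of compounds 1 and 3. Nothing at hand accounts for the split between the two pairs.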